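The source may report more compounds than this note shows. Statements on the series, on what has been measured and on what is new or still open speak of the compounds shown alone.

Measured so far:
compound 1 `N=C(NCCCc1c[nH]cn1)NCCCC(c1ccccc1)c1ccccn1`, in a functional assay on cardiac atrium for agonist activity at histamine H2 receptor (Cavia porcellus) (a lower number here means a smaller maximal response, a higher number a larger maximal response), giving 1
compound 2 `N=C(NCCCc1c[nH]cn1)NCCC(c1ccccc1)c1ccccn1`, giving 1 in this assay
compound 3 `Cc1ccc(C(CC/N=C(\N)NCCCc2c[nH]cn2)c2ccccn2)cc1`, giving 1 in this assay

All three compounds share a common core and differ only in the chain length and in the substitution on the phenyl ring. In this assay compound 1, compound 2 and compound 3 reach the same maximal response at the digits recorded, and no ordering among them can be read from these numbers: compound 3 is level with compound 1 and level with compound 2, both within the scatter. No pair of these compounds differs in one place only, so no single-point step has been measured within the series; what can be said is only that the full response is kept across the three.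

Compound 4 `N/C(=N\CCC(c1ccc(O)cc1)c1ccccn1)NCCCc1c[nH]cn1` is not yet measured. It differs from compound 3 by hydroxy in place of methyl on an aromatic carbon, that is, a hydroxy in place of a methyl on the 4-methylphenyl, turning it into a 4-hydroxyphenyl. Going by the values given here, since every compound measured so far reaches the full response in this assay, the step in this assay from compound 3 to compound 4 is expected to be none beyond the scatter, no change at the digits printed from compound 3 to compound 4 (within the scatter). Compound 4 is therefore estimated to give 1 in this assay, within a range from 0.85 to 1.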

Compound 4, intrinsic activity: the largest response reached, as a fraction of the reference agonist's: 1
Compound 4: middle estimate and measured number agree at the digits printed; the range from low to high includes it.
By their numbers in this assay, from the lowest: compounds 1, 2, 3 and 4 (each within the scatter of the next).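

The series now has its first step at a single place: in this assay, hydroxy in place of methyl on an aromatic carbon gives no change at the digits printed from compound 3 to compound 4 (within the scatter). Going by these compounds alone, at this position, then, the maximal response holds when the 4-methylphenyl is replaced by the 4-hydroxyphenyl, even though the entering group brings a hydrogen-bond donor and a hydrogen-bond acceptor that the methyl lacks; the earlier compounds, with no pair differing in one place, could not show this for any single change. No supporting measurement is available to account for this outcome.

Going by these compounds, it remains open whether the maximal response would hold with other groups on this aromatic carbon, such as an amine, a carboxylic acid or a methoxy group, or with a longer chain in the same 4-hydroxyphenyl compound. On these data alone, the read-out gives only the largest response reached, so the concentration each compound needs to reach that response also remains open.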